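Thiophen-2-yl for Furan-2-yl on the Chloro Analogue

The compounds below may be only part of what the source reports. "The series", "measured", "known", "first", "only" and "open" are said of these compounds alone.

Of the compounds shown here, three built on a shared core have been measured in an ADME assay on microsomes from liver (Rattus norvegicus) for metabolic stability, read by LC-MS, using NADPH, tested at 3 uM; a higher number here means that the compound lasts longer, a lower number that the compound disappears faster. Compound 1 `Cc1ccc2c(C(CC(F)(F)F)c3cccs3)c(-c3ccccc3)[nH]c2c1` gives 0.292 h. Compound 2 `Cc1ccc2c(C(CC(F)(F)F)c3ccco3)c(-c3ccccc3)[nH]c2c1` gives 0.172 h in this assay. Compound 3 `FC(F)(F)CC(c1ccco1)c1c(-c2ccccc2)[nH]c2cc(Cl)ccc12` gives 0.772 h in this assay, the highest number of the three.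

Two single-point changes connect them. From compound 2 to compound 1 the change is thiophen-2-yl in place of furan-2-yl on a saturated chain carbon bound to an aromatic carbon and a saturated chain carbon, and this brought a 1.7-fold higher number from compound 2 to compound 1 (0.23 log units; within the scatter). The cores of compound 2 and compound 3 differ by chloro in place of methyl on an aromatic carbon, which brought a 4.5-fold higher number from compound 2 to compound 3 (0.65 log units; beyond the scatter).

Compound 4 `FC(F)(F)CC(c1cccs1)c1c(-c2ccccc2)[nH]c2cc(Cl)ccc12` has not yet been measured. It differs from compound 3 by thiophen-2-yl in place of furan-2-yl on a saturated chain carbon bound to an aromatic carbon and a saturated chain carbon. This is the same change as from compound 2 to compound 1, made at the same place in the words given, and it occurs twice among the four compounds.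

Among the measured compounds shown here, for compound 4 the expectation in this assay is a step of a 1.4-fold higher number from compound 3 to compound 4 (0.15 log units; within the scatter), set beside the earlier 1.7-fold higher number from compound 2 to compound 1 (0.23 log units; within the scatter), which rests on the single measured instance of this change and on the starting point of compound 3 at 0.772 h. Since that earlier step lay within the scatter, compound 4 is expected to sit near compound 3 or somewhat higher. Compound 4 is therefore estimated to give 1.1 h in this assay, with a likely range from 0.55 h to 2.2 h.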

Compound 4, half-life: 0.905 h
Compound 4: the middle estimate sits 1.2-fold (0.08 log units) above what was measured; low and high end bracket the measured number.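

In this assay, thiophen-2-yl in place of furan-2-yl gave a 1.2-fold higher number from compound 3 to compound 4 (0.07 log units; within the scatter), and this step agrees with the one seen earlier on the core bearing methyl, so on both cores the change leaves the number within the usual scatter: the same change on two cores in this assay, a 1.7-fold higher number (0.23 log units; within the scatter) from compound 2 to compound 1 and a 1.2-fold higher number (0.07 log units; within the scatter) from compound 3 to compound 4, 1.4-fold (0.16 log units) apart, within the scatter of two such steps. Chloro in place of methyl gave a 3.1-fold higher number from compound 1 to compound 4 (0.49 log units; beyond the scatter), a step beyond the scatter, and it carried over from the furan-2-yl pair to the thiophen-2-yl pair with a higher number each time: the same change on two cores in this assay, a 4.5-fold higher number (0.65 log units; beyond the scatter) from compound 2 to compound 3 and a 3.1-fold higher number (0.49 log units; beyond the scatter) from compound 1 to compound 4, 1.4-fold (0.16 log units) apart, within the scatter of two such steps. Together the two comparisons show that, across these four compounds, the two changes act independently of each other within the scatter, but each rests on only two steps, and they show neither why the number moves nor whether the same would hold on a different core.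

The compounds shown leave open whether a phenyl or a pyridin-2-yl group on the same saturated chain carbon would follow the furan-2-yl and thiophen-2-yl pair. They also leave open how fluoro or methoxy in place of chloro would compare, and whether a longer fluorinated chain would change either step.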